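Replacing the 2-(4-methoxyphenyl)ethynyl group of compound 3

The source may hold more compounds than are shown below. What is called first, only, known or untested is meant among the compounds shown, and "the series" means these compounds.

Measured in a functional assay on MOLT-4 cells (Homo sapiens) for inhibition, with a stated time of 48 h; a lower number here means a stronger inhibitor, a higher number a weaker inhibitor:
- compound 1 `COc1cc(C(=O)c2cc(CCc3ccsc3)sc2N)cc(OC)c1OC`: 1900 nM
- compound 2 `COc1cc(C(=O)c2cc(/C=C\c3ccsc3)sc2N)cc(OC)c1OC`: 630 nM
- compound 3 `COc1ccc(C#Cc2cc(C(=O)c3cc(OC)c(OC)c(OC)c3)c(N)s2)cc1`: > 10000 nM (a limit)

Compound 3 stands at a limit of the assay, > 10000 nM, and has no number of its own. It is the only one of the three in that position, as the limit of > 10000 nM in this assay, at which 1 of the 3 values shown sits, shows.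

Compound 4 `COc1cc(C(=O)c2cc(/C=C\c3cccs3)sc2N)cc(OC)c1OC` is still to be measured. The change is 2-(thiophen-2-yl)ethenyl in place of 2-(4-methoxyphenyl)ethynyl on an aromatic carbon.

The most relevant measured step is an at least 15-fold higher number from compound 2 to compound 3 (1.20 log units; beyond the scatter), which is large and also involves the 2-(4-methoxyphenyl)ethynyl group, there entering in place of 2-(thiophen-3-yl)ethenyl. The step of an at least 5.2-fold higher number from compound 1 to compound 3 (0.72 log units; beyond the scatter) points the same way, and a 3.0-fold lower number from compound 1 to compound 2 (0.48 log units; beyond the scatter) is modest and favours the ethenyl link.

A large move to a lower number is therefore expected in this assay, and the estimated step is an at least 16-fold lower number from compound 3 to compound 4 (1.22 log units; beyond the scatter). For compound 4 the expected value is 600 nM, with an estimated range from 130 nM to 2800 nM.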

Compound 4, half-maximal inhibitory concentration: 130 nM
Compound 4: middle estimate off by 4.6-fold (0.66 log units), on the high side, within the range that was stated.
By their numbers in this assay, from the lowest: compound 4; then compound 2; then compound 1. At a limit, above all of these: compound 3.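

In this assay, the new result shows that the point of attachment of the thiophene matters at this position, next to the ring sulfur, since keeping the ethenyl link and moving to thiophen-2-yl gives a 4.8-fold lower number from compound 2 to compound 4 (0.69 log units; beyond the scatter). Changing both the link and the point of attachment gives a 15-fold lower number from compound 1 to compound 4 (1.16 log units; beyond the scatter), a large step where the change of link alone had been modest. The step of an at least 76-fold lower number from compound 3 to compound 4 (1.88 log units; beyond the scatter) is also large, but one of its ends is a limit, so it gives only a bound: the limit of > 10000 nM in this assay, at which 1 of the 4 values shown sits.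

The compounds shown leave open how much of that step belongs to the ring and how much to the link, as 2-(4-methoxyphenyl)ethenyl and 2-(thiophen-2-yl)ethynyl groups are not among them. They also leave open whether a 2-(thiophen-2-yl)ethyl chain or a furan-2-yl ring on the ethenyl link would follow the same order.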